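Polybrominated Diaryl Ethers: Ester Side Chain to Bromopentyl

The source may hold more compounds than are shown below. What is called first, only, known or untested is meant among the compounds shown, and "the series" means these compounds.

Of the compounds shown here, three sharing one core have been measured in a functional assay on HL-60 cells (Homo sapiens) for cytotoxicity, read by MTT assay, with a stated time of 24 h; on this read-out higher numbers stand for weaker inhibition and lower numbers for stronger inhibition. Compound 1 `OCCOc1c(Br)cc(Br)cc1Oc1ccc(Br)cc1Br` gives 28.2 ug/mL. Compound 2 `BrCCCOc1c(Br)cc(Br)cc1Oc1ccc(Br)cc1Br` gives 29.9 ug/mL. Compound 3 `CCOC(=O)C(C)Oc1c(Br)cc(Br)cc1Oc1ccc(Br)cc1Br` gives 35.7 ug/mL. Compound 3 thus carries the highest of the three numbers, yet the steps leading to it are small, a 1.3-fold higher number from compound 1 to compound 3 (0.10 log units; within the scatter) and a 1.2-fold higher number from compound 2 to compound 3 (0.08 log units; within the scatter), so nothing sets it apart from the others beyond the usual scatter.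

Compound 4 `BrCCCCCOc1c(Br)cc(Br)cc1Oc1ccc(Br)cc1Br` differs from compound 3 in one place: 5-bromopentyl in place of 1-(ethoxycarbonyl)ethyl on an oxygen on an aromatic ring. The measured steps that bear on this are exchanges of one side chain for another on the same oxygen. a 1.2-fold higher number from compound 2 to compound 3 (0.08 log units; within the scatter) shows that trading 3-bromopropyl for 1-(ethoxycarbonyl)ethyl changed little, and a 1.1-fold higher number from compound 1 to compound 2 (0.03 log units; within the scatter) shows that bromomethyl in place of hydroxy on that chain changed little as well. For the measured compounds named here, the 5-bromopentyl chain of compound 4 is longer than the 3-bromopropyl chain of compound 2, which no measured pair covers. The expectation for compound 4 in this assay is therefore a number close to that of compound 3, a 1.2-fold lower number from compound 3 to compound 4 (0.08 log units; within the scatter), with no step beyond the scatter. Compound 4 is estimated at 30 ug/mL, in a range from 18 ug/mL to 50 ug/mL.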

Compound 4, half-maximal inhibitory concentration: 25.7 ug/mL
Estimate against measurement, compound 4: 1.2-fold (0.07 log units) above, within the range that was stated.
By their numbers in this assay, from the lowest: compounds 4, 1, 2 and 3 (each within the scatter of the next).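

In this assay, 5-bromopentyl in place of 1-(ethoxycarbonyl)ethyl on the oxygen gives a 1.4-fold lower number from compound 3 to compound 4 (0.14 log units; within the scatter), so a side chain with 0 hydrogen-bond acceptors and no double bond stands within the scatter of an ester chain with 2 hydrogen-bond acceptors and 1 double bond. The longest chain in the set adds the same picture at this oxygen, with a 1.2-fold lower number from compound 2 to compound 4 (0.07 log units; within the scatter) and a 1.1-fold lower number from compound 1 to compound 4 (0.04 log units; within the scatter), so across the 2-hydroxyethyl, 3-bromopropyl and 5-bromopentyl chains and the ester chain, no exchange at this position has yet moved the number beyond the scatter. Nothing accompanying these compounds accounts for this flat response.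

The compounds shown leave open whether a terminal amine or a carboxylic acid on the chain, or a chain longer than 5-bromopentyl, would give a step beyond the scatter in this assay. They also leave open whether a free hydroxy in place of the whole ether side chain would do so, and whether any change on the shared core matters more than changes on this oxygen.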